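Returning from a phenoxy link to a direct biaryl

A few compounds are considered here, and "the series" means these few. Any claim that something is new, unique, unknown or untested is made for them only; others in the source may bear on it.

Compound 3 `COc1cccc(Oc2ccc([C@H]3S[C@@H](C)C(=O)Nc4c3c(C)nn4-c3ccccc3C)cc2)c1` stands highest among the three measured compounds: in an assay on isolated protein for agonist activity at Bile acid receptor (Homo sapiens), read by AlphaScreen, with a stated time of 30 min (on this read-out lower numbers stand for smaller maximal responses and higher numbers for larger maximal responses), compound 3 reaches 120%. Its two neighbours are compound 1 `Cc1ccccc1-n1nc(C)c2c1NC(=O)[C@H](C)S[C@@H]2c1ccc(-c2ccccc2)cc1`, which in this assay gives 24%, and compound 2 `CCOc1cccc(-c2ccc([C@H]3S[C@@H](C)C(=O)Nc4c3c(C)nn4-c3ccccc3C)cc2)c1`, which gives 13%. The difference from compound 1 to compound 3 is a number 96 percentage points higher from compound 1 to compound 3 (beyond the scatter), and from compound 2 to compound 3 it is a number 107 percentage points higher from compound 2 to compound 3 (beyond the scatter); between the two biaryls themselves the step is a number 11 percentage points lower from compound 1 to compound 2 (beyond the scatter).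

Compound 4 `COc1ccccc1-c1ccc([C@H]2S[C@@H](C)C(=O)Nc3c2c(C)nn3-c2ccccc2C)cc1` differs from compound 3 in one place: 2-methoxyphenyl in place of 3-methoxyphenoxy on an aromatic carbon. Both measured steps that bear on this involve swapping a directly attached phenyl or 3-ethoxyphenyl for the 3-methoxyphenoxy group, and both were large. Compound 4 goes the other way, back to a directly attached ring carrying a single methoxy, so a large drop in this assay is expected, roughly of the size seen in reverse; the step from compound 3 to compound 4 is estimated as a number 95 percentage points lower from compound 3 to compound 4 (beyond the scatter). Compound 4 is therefore expected to give about 25%, with a likely range from 5% to 60%.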

Compound 4, largest response reached (reported as efficacy), in percent of the reference or control that the assay uses: 50%
Beside the measured number, compound 4's estimate is 25 percentage points below it, and the stated range covers the measured number.
By their numbers in this assay, from the lowest: compound 2; then compound 1; then compound 4; then compound 3.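

In this assay, replacing the 3-methoxyphenoxy group with a directly attached 2-methoxyphenyl costs much of the response (a number 70 percentage points lower from compound 3 to compound 4 (beyond the scatter)), yet a directly attached ring does not always give a response as low as those of the first two biaryls. The methoxy on the added ring brings a gain over the bare phenyl (a number 26 percentage points higher from compound 1 to compound 4 (beyond the scatter)), and the 2-methoxyphenyl also stands well clear of the 3-ethoxyphenyl (a number 37 percentage points higher from compound 2 to compound 4 (beyond the scatter)), so the group carried on a directly attached ring clearly matters. Nothing available here explains these differences.

As far as these compounds go, a directly attached 3-methoxyphenyl would help separate the effect of the oxygen link from that of where the methoxy sits, and its result remains open. From the compounds shown here alone, the effect of an amine or a carboxylic acid on the added ring also remains open.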